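The source may hold more compounds than are shown below. What is called first, only, known or untested is meant among the compounds shown, and "the series" means these compounds.

Working notes on the series. Compound 1 `COc1cccc(F)c1-c1cccc2nc(N)oc12` carries a free amino group on the shared core; compound 2 `COc1cccc(F)c1-c1cccc2nc(Nc3ccccc3)oc12` has phenyl on that nitrogen, and compound 3 `COc1cccc(Nc2nc3cccc(-c4c(F)cccc4OC)c3o2)n1` has 6-methoxypyridin-2-yl there. In an assay on BAF cells for inhibition of ribosomal protein S6 kinase alpha-2 (Mus musculus) (on this read-out higher numbers stand for weaker inhibition and lower numbers for stronger inhibition), compound 1 reaches only a limit, > 20000 nM. In this assay compound 2 likewise stops at a limit, > 20000 nM. Compound 3 in this assay also gives no number but a limit, > 20000 nM. Compound 3 thus stands level with the other two at the edge of the measurable range, as summed up by the limit of > 20000 nM in this assay, at which 3 of the 3 values shown sit. The steps a step that the two limits leave unreadable from compound 1 to compound 2, a step that the two limits leave unreadable from compound 1 to compound 3 and a step that the two limits leave unreadable from compound 2 to compound 3 are all unreadable, since a limit sits at both ends of each.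

Compound 4 `COc1ccc(Nc2nc3cccc(-c4c(F)cccc4OC)c3o2)cc1` differs from compound 3 by 4-methoxyphenyl in place of 6-methoxypyridin-2-yl on a nitrogen on an aromatic ring. Within the data shown here, the only measured step that swaps one ring for another on this nitrogen, a step that the two limits leave unreadable from compound 2 to compound 3, carries no readable size, and the two other steps are equally mute. The step that the limit leaves unreadable from compound 3 to compound 4 expected for this change therefore has no measured size or direction to rest on. Compound 4 is estimated at 30000 nM, with a range from 8000 nM to 100000 nM, and is expected most likely to be reported again only as a limit in this assay.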

Compound 4, half-maximal inhibitory concentration: > 20000 nM
Compound 4 ended at the assay's limit (the forecaster's own chance of this, stated with the estimate: 80%); the middle value is on the limit's open side.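

In this assay compound 4 gives only a limit, so no step from compound 1, compound 2 or compound 3 to compound 4 can be read, and the series stays at a single edge: the limit of > 20000 nM in this assay, at which 4 of the 4 values shown sit.

The compounds shown leave open whether any group on this nitrogen gives a measurable value in this assay, and how large any difference among them is.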